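A Thioether in Place of a Ketone on the Shared Core

A few compounds are considered here, and "the series" means these few. Any claim that something is new, unique, unknown or untested is made for them only; others in the source may bear on it.

Measured so far in an ADME assay on cells (Homo sapiens) for cytotoxicity, read by resazurin assay, with a stated time of 5 days; on this read-out higher numbers stand for lower toxicity in this test and lower numbers for higher toxicity in this test:
Compound 1 `COc1ccc(-c2nc(CC(=O)c3cccc(Cl)c3)nc3ccsc23)cn1` gives 30000 nM.
Compound 2 `O=S(=O)(Cc1nc(-c2ccncc2)c2sccc2n1)c1cccc(Cl)c1` gives > 50000 nM, which is a limit of the assay and not a number.
Compound 3 `O=S(=O)(Cc1nc(-c2ccc(F)nc2)c2sccc2n1)c1cccc(Cl)c1` gives 40000 nM.

Among the two numbers, compound 1 cannot be set apart from compound 3, since the two lie within the scatter of each other, and compound 2 gave only a limit. Within the data shown here, the one step measured in a single place is an at least 1.2-fold lower number from compound 2 to compound 3 (0.09 log units; that floor lies within the scatter), and its floor lies within the scatter; it also concerns (the limit of > 50000 nM in this assay, at which 1 of the 3 values shown sits), so it tells little about size.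

Compound 4 `COc1ccc(-c2nc(CSc3cccc(Br)c3)nc3ccsc23)cn1` differs from compound 1 by (3-bromophenyl)sulfanyl in place of (3-chlorophenyl)carbonyl on a saturated chain carbon bound to an aromatic carbon. Among the measured compounds shown here, no measured step touches this part of the molecule, so the expectation rests on compound 1 alone, whose value 30000 nM is taken as the anchor. No step beyond the scatter is expected in this assay. Compound 4 is therefore estimated at 30000 nM, with a range from 10000 nM to 60000 nM. That estimate means no change at the digits printed from compound 1 to compound 4 (within the scatter).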

Compound 4, half-maximal cytotoxic concentration: > 50000 nM
Compound 4: no number, only a limit (the forecaster's own chance of this, stated with the estimate: 30%); middle value at least 1.6-fold (0.22 log units) away from the limit.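

In this assay, among these compounds, replacing (3-chlorophenyl)carbonyl with (3-bromophenyl)sulfanyl on a saturated chain carbon bound to an aromatic carbon gives an at least 1.6-fold higher number from compound 1 to compound 4 (0.22 log units; that floor lies within the scatter), the first measured step at this position, and its floor does not show a real change. The value of compound 4, > 50000 nM, is a limit of the assay and not a number, so the full size of the step cannot be read. This limit is also not alone among the compounds shown: the limit of > 50000 nM in this assay, at which 2 of the 4 values shown sit.

From the compounds shown here alone, the carbonyl-to-sulfanyl change and the chlorine-to-bromine change come together in this step, so the share of each remains open. Also open, going by these compounds, is how an amine or a carboxylic acid in place of the bromine would read in this assay.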